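The source may hold more compounds than are shown below. What is called first, only, known or untested is meant among the compounds shown, and "the series" means these compounds.

Measured so far:
- compound 1, `O=C1O[C@H]([C@@H](O)Cn2cc(-c3cccc(O)c3)nn2)C(OCc2ccccc2)=C1OCc1ccccc1`: 51800 nM
- compound 2, `COc1ccc(-c2cn(C/C=C3\OC(=O)C(OCc4ccccc4)=C3OCc3ccccc3)nn2)cc1`: 39100 nM

Two compounds have been run in a functional assay on MCF7 cells (Homo sapiens) for antiproliferative activity, read by MTT assay, with a stated time of 72 h; on this read-out lower numbers stand for stronger inhibition and higher numbers for weaker inhibition. Compound 1 gives 51800 nM and compound 2 gives 39100 nM; the gap between them lies within the usual scatter of this assay, so neither is set apart from the other, and both sit in a region of weak inhibition. Going by the values given here, no step between compounds differing in one place has been measured, so nothing is known here about how single changes on the shared core move the read-out.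

The next compound is compound 3, `O=C1O[C@H]([C@@H](O)Cn2cc(CNS(=O)(=O)c3ccc(Cl)cc3)nn2)C(OCc2ccccc2)=C1OCc1ccccc1`. Relative to compound 1 the change is (((4-chlorophenyl)sulfonyl)amino)methyl in place of 3-hydroxyphenyl on an aromatic carbon. Among the compounds with values here, the only guidance is the pair of weak values already seen; there is no measured precedent for this kind of exchange on the five-membered ring. The expectation is therefore a step of no clear direction, not beyond the scatter: a 1.2-fold lower number from compound 1 to compound 3 (0.06 log units; within the scatter). On that basis compound 3 is estimated at 45000 nM, with a range from 15000 nM to 140000 nM, the breadth reflecting the absence of a measured step for this change.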

Compound 3, half-maximal inhibitory concentration: 4170 nM
Compound 3: the middle estimate sits 11-fold (1.03 log units) above what was measured, and the stated range ends above it.
By their numbers in this assay, from the lowest: compound 3; then compounds 2 and 1 (each within the scatter of the next).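

Going by these compounds alone, the aromatic carbon of the five-membered aromatic ring with 3 nitrogen is a place where a single exchange moves the read-out in this assay: (((4-chlorophenyl)sulfonyl)amino)methyl in place of 3-hydroxyphenyl gives a 12-fold lower number from compound 1 to compound 3 (1.09 log units; beyond the scatter) and is the only measured step so far, so the weak values of the earlier compounds are not fixed by the shared core alone. Both groups carry one six-membered aromatic ring of carbon only and 1 hydrogen-bond donor, while the entering group has 12 heavy atoms against 7 and adds nitrogen, sulfur, chlorine and 2 double bonds outside aromatic rings; all of these change together, and this one step does not separate them. Nothing measured here explains why the read-out moves.

Still open, from the compounds shown here alone, is which part of the entering group carries the step: the same group without its chlorine, or a plain aminomethyl group, would begin to separate the parts. Also open, going by these compounds, is how a carboxylic acid at this place would read, and whether the same exchange gives a step of similar size on the core of compound 2.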